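From 1H-indol-5-yl to 1H-indol-6-yl

The source may report more compounds than this note shows. Statements on the series, on what has been measured and on what is new or still open speak of the compounds shown alone.

Measured in a functional assay on MCF7 cells (Homo sapiens) for cytotoxicity, read by MTT assay, with a stated time of 48 h; a lower number here means a stronger inhibitor, a higher number a weaker inhibitor:
- compound 1 `COc1ccc(-c2nc3ccccn3c2C(=O)/C=C\Nc2ccc3cc[nH]c3c2)cc1` gives 19400 nM
- compound 2 `COc1cc(N/C=C\C(=O)c2c(-c3ccc(Cl)cc3)nc3ccccn23)cc(OC)c1` gives 13600 nM
- compound 3 `O=C(/C=C\Nc1ccc2[nH]ccc2c1)c1c(-c2ccc(Cl)cc2)nc2ccccn12` gives 7130 nM

The number for compound 3 lies within the scatter of the number for compound 2, and the number for compound 1 stands higher than both, beyond the scatter of compound 3. Compound 4 `O=C(/C=C\Nc1ccc2cc[nH]c2c1)c1c(-c2ccc(Cl)cc2)nc2ccccn12` differs from compound 3 in one place: 1H-indol-6-yl in place of 1H-indol-5-yl on an amine nitrogen. This puts 1H-indol-6-yl in place of 1H-indol-5-yl on an amine nitrogen. Within the data shown here, the one measured step that bears on this, a 1.9-fold lower number from compound 2 to compound 3 (0.28 log units; within the scatter), swapped a different group for 1H-indol-5-yl. Among the measured compounds shown here, no measured step isolates this exact change, so no step beyond the scatter is expected in this assay. The expected step is a 1.1-fold higher number from compound 3 to compound 4 (0.05 log units; within the scatter). The estimate for compound 4 is 8000 nM, with an expected range from 3500 nM to 18000 nM.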

Compound 4, half-maximal inhibitory concentration: 9600 nM
The estimate for compound 4 lay 1.2-fold (0.08 log units) below the measured number; the measured number falls inside the stated range.
By their numbers in this assay, from the lowest: compounds 3, 4, 2 and 1 (each within the scatter of the next, the first and the last beyond it).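

In this assay, 1H-indol-6-yl in place of 1H-indol-5-yl on the amine nitrogen gives a 1.3-fold higher number from compound 3 to compound 4 (0.13 log units; within the scatter) and so leaves the two attachments indistinguishable. Against 3,5-dimethoxyphenyl, 1H-indol-6-yl gives a 1.4-fold lower number from compound 2 to compound 4 (0.15 log units; within the scatter) and also stays inside the scatter. Chloro in place of methoxy on an aromatic carbon, with 1H-indol-6-yl kept, gives a 2.0-fold lower number from compound 1 to compound 4 (0.31 log units; beyond the scatter) as the only new step beyond the scatter, and no measurement here explains these numbers.

Still open, from the compounds shown here alone, is whether bromo or trifluoromethyl in place of chloro would shift the number further. Also open, going by these compounds, is how 1H-indol-4-yl on the amine nitrogen would compare with the two indolyl groups.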